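Methyl for Methoxy on the 3-Methoxyphenyl Group of Compound 1

A few compounds are considered here, and "the series" means these few. Any claim that something is new, unique, unknown or untested is made for them only; others in the source may bear on it.

Compound 1 `COC(=O)/C=C/c1cccc(N(Cc2ccc(-c3cccc(OC)c3)cc2)C(=O)NC(C)C)c1` is the weakest binder among the three compounds measured here. In an assay on isolated protein with Bile acid receptor (Homo sapiens) as the target (on this read-out higher numbers stand for an effect only at larger amounts of compound and lower numbers for an effect already at smaller amounts), compound 1 gives 1370 nM. Compound 2 `CCOC/C=C/c1cccc(N(Cc2ccc(/C=C/C(=O)OC(C)(C)C)cc2)C(=O)C2CCCCC2)c1` differs from compound 1 at several positions; in this assay compound 2 gives 220 nM. Compound 3 `COC(=O)/C=C/c1cccc(N(Cc2ccc(-c3cccc(OC)c3)cc2)C(=O)C(C)C)c1`, with a 19-fold lower number from compound 1 to compound 3 (1.28 log units; beyond the scatter), gives 72 nM. That step concerns the carbonyl substituent alone and leaves the aromatic rings untouched.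

Compound 4 `COC(=O)/C=C/c1cccc(N(Cc2ccc(-c3cccc(C)c3)cc2)C(=O)NC(C)C)c1` differs from compound 1 by methyl in place of methoxy on an aromatic carbon. Among the measured compounds shown here, none of the measured steps touches this part of the molecule: the step from compound 1 to compound 3 changes the carbonyl substituent, and compound 2 differs from compound 1 in too many places to isolate the contribution of one ring substituent. The data therefore offer no direct guide for what the exchange of methoxy for methyl will do in this assay.

For the measured compounds named here, with no step on this position to lean on, the expectation for compound 4 is a change of a 1.1-fold lower number from compound 1 to compound 4 (0.06 log units; within the scatter), not clearly beyond the scatter in either direction. Compound 4 is thus estimated to give 1200 nM in this assay, within a range from 350 nM to 4000 nM.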

Compound 4, half-maximal effective concentration: 1330 nM
Beside the measured number, compound 4's estimate is 1.1-fold (0.04 log units) below it, and the stated range covers the measured number.
By their numbers in this assay, from the lowest: compound 3; then compound 2; then compounds 4 and 1 (each within the scatter of the next).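

In this assay, exchanging 3-methoxyphenyl for 3-methylphenyl gives a 1.0-fold lower number from compound 1 to compound 4 (0.01 log units; within the scatter), so with the isopropylamino carbonyl in place, the oxygen of the methoxy group and its one hydrogen-bond acceptor can go without a readable change in the number. This is the only step shown at this ring substituent, and set against a 19-fold lower number from compound 1 to compound 3 (1.28 log units; beyond the scatter), which concerns the carbonyl substituent alone, it shows that a change at the carbonyl can move the number well beyond the scatter while this particular change at the ring does not. No measurement presented here explains why the methoxy and methyl compounds read alike.

The compounds shown test this exchange only with the isopropylamino carbonyl of compound 1, so it remains open whether methyl and methoxy would also read alike with the isopropyl carbonyl of compound 3, whose number is far lower. Going by these compounds, it also remains open whether this place on the ring would stay as flat with a different kind of group there, such as an amine, a carboxylic acid or a longer alkoxy chain.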